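From 3,4-difluorophenyl to 2-methoxyphenyl on a shared core

The compounds below may be only part of what the source reports. "The series", "measured", "known", "first", "only" and "open" are said of these compounds alone.

In an ADME assay on L6 cells (Rattus norvegicus) for cytotoxicity, read by resazurin assay, with a stated time of 70 h (a lower number here means a stronger inhibitor, a higher number a weaker inhibitor), compound 1 `CC(=O)Oc1ccc2c(c1)C(C)=CC(C)(C)N2Cc1ccccc1` gives 18000 nM, and compound 2 `CC(=O)Oc1ccc2c(c1)C(C)=CC(C)(C)N2Cc1ccc(F)c(F)c1` gives 17000 nM. With only these two numbers available, compound 2 stands level with compound 1, as the two values lie within the scatter of each other.

Compound 3 `COc1ccccc1CN1c2ccc(OC(C)=O)cc2C(C)=CC1(C)C` keeps the shared core and its acetate but carries 2-methoxyphenyl in place of 3,4-difluorophenyl on a saturated chain carbon bound to a nitrogen on an aromatic ring in a ring.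

Among the measured compounds shown here, only one measured step bears on this change. Putting 3,4-difluorophenyl in place of phenyl at that same place gave a 1.1-fold lower number from compound 1 to compound 2 (0.02 log units; within the scatter). For the measured compounds named here, that single step is the only guide, and no measured compound carries 2-methoxyphenyl, so the evidence is thin and the range is kept wide. No shift beyond the scatter is expected in this assay, and the estimated step is a 1.1-fold lower number from compound 2 to compound 3 (0.03 log units; within the scatter). Compound 3 is expected to give about 16000 nM, with an estimated range from 6000 nM to 40000 nM.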

Compound 3, half-maximal inhibitory concentration: 17000 nM
Compound 3: the middle estimate sits 1.1-fold (0.03 log units) below what was measured; measured number inside the range.
By their numbers in this assay, from the lowest: compounds 2, 3 and 1 (each within the scatter of the next).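

In this assay there is no change at the digits printed from compound 2 to compound 3 (within the scatter) when 2-methoxyphenyl replaces 3,4-difluorophenyl on a saturated chain carbon bound to a nitrogen on an aromatic ring in a ring, and a 1.1-fold lower number from compound 1 to compound 3 (0.02 log units; within the scatter) when methoxy replaces hydrogen on an aromatic carbon. Until now only a group carrying fluorine had been compared with phenyl at this place; a group with no fluorine and with a hydrogen-bond acceptor also stays within the scatter, so across these three compounds neither kind of substituent separates the readings. Nothing measured here offers an explanation for this flat result.

The compounds shown leave open whether anything other than a substituted phenyl at this place, such as a chain ending in an amine or a carboxylic acid, would move the number beyond the scatter. From the compounds shown here alone, the acetate on the shared core also stays the same throughout, so it remains open whether the readings would hold with a free hydroxyl or an amide in its stead.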